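The source may hold more compounds than are shown below. What is called first, only, known or untested is meant among the compounds shown, and "the series" means these compounds.

The study sets two cores side by side. Compound 1 `OC1C#CCCCCC#C/C1=C\c1ccccc1` is the hydroxy member of the first core, and compound 3 `CC(=O)OC1C#CCCCCC#C/C1=C\c1ccccc1` is its acetyl counterpart. Compound 2 `OC1C#CCCCCC#C/C1=C\c1cccc2ccccc12` and the still unmeasured compound 4 `CC(=O)OC1C#CCCCCC#C/C1=C\c1cccc2ccccc12` form the matching pair on the second core; how the core of compound 2 differs from the core of compound 1 is not broken down here.

In a functional assay on P388 cells (Mus musculus) for inhibition, read by MTT assay (a lower number here means a stronger inhibitor, a higher number a weaker inhibitor), compound 1 gives 25000 nM. In this assay compound 3 gives 48000 nM, and compound 2 gives 41000 nM. The change on the first core is acetyl in place of hydrogen on an oxygen on a saturated carbon, and it made a step of a 1.9-fold higher number from compound 1 to compound 3 (0.28 log units; within the scatter).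

The change on the second core is acetyl in place of hydrogen on an oxygen on a saturated carbon; its place reads word for word as the first, so it is the same change. Because the first pair showed a 1.9-fold higher number from compound 1 to compound 3 (0.28 log units; within the scatter), the expected step for the second pair is a 1.6-fold higher number from compound 2 to compound 4 (0.20 log units; within the scatter). Compound 4 is therefore estimated at 65000 nM in this assay, with a likely range from 30000 nM to 150000 nM.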

Compound 4, half-maximal inhibitory concentration: 2400 nM
Beside the measured number, compound 4's estimate is 27-fold (1.43 log units) above it; the measured number lies below the stated range.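

On the core of compound 2, acetyl in place of hydrogen on the oxygen gives a 17-fold lower number from compound 2 to compound 4 (1.23 log units; beyond the scatter), making compound 4 a clearly stronger inhibitor than compound 2 in this assay. This change therefore did not carry over from one core to the other with the same effect in this assay: the same change on two cores in this assay, a 1.9-fold higher number (0.28 log units; within the scatter) from compound 1 to compound 3 and a 17-fold lower number (1.23 log units; beyond the scatter) from compound 2 to compound 4, 33-fold (1.52 log units) apart, beyond the scatter of two such steps. Among these compounds, the pairs show that the step from this change depends on the core that carries it, but they do not show which feature of the cores matters or how the change works, and each core is represented by only one pair.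

The compounds shown leave open whether a propionyl or benzoyl group on the same oxygen, or a methyl ether in place of the hydroxy, would give a step like that on the core of compound 2 or like that on the core of compound 1. They also leave open whether an amine at that place would follow either pair, and how the acetyl change behaves on any further core.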